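This account rests on a few compounds, and the source may have more. Where it says the series, first, only, none or still open, it means among the compounds named here.

Measured compounds:
Compound 1, `CNC(=O)/C=C1\CCc2cc(F)c(F)cc21`: 96 mg/kg
Compound 2, `CC(C)NC(=O)/C=C1\CCc2ccc(F)cc21`: 96 mg/kg
Compound 3, `NC(=O)/C=C1\CCc2ccccc21`: 108 mg/kg

All three were tested in a functional assay on the whole organism with Mus musculus as the target; on this read-out lower numbers stand for an effect already at smaller amounts and higher numbers for an effect only at larger amounts of compound. Compound 2 gives the same number as compound 1 at the digits shown, and the number for compound 3 differs from that of compound 2 only within the usual scatter of repeated measurements. Among the compounds with values here, on the numbers at hand, compound 2 therefore sits in a tight group with the other two, and no compound can be called more or less active than another.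

The next compound, compound 4, `O=C(/C=C1\CCc2ccc(F)cc21)NC1CC1`, has not yet been measured in this assay. It differs from compound 2 in one place: cyclopropyl in place of isopropyl on an amide-type nitrogen. The new group is of the same size as the one it replaces, and it carries no donors, acceptors or charge, just like the group it replaces. Within the data shown here, no measured pair shows how this particular change plays out.

Given how close all three measured numbers lie, the step of no change at the digits printed from compound 2 to compound 4 (within the scatter) is expected to be none beyond the scatter. Compound 4 is estimated to give 96 mg/kg in this assay, with a range from 48 mg/kg to 190 mg/kg.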

Compound 4, dose for half-maximal effect: 66 mg/kg
For compound 4 the middle estimate is 1.5-fold (0.16 log units) above the measured one, and the stated range covers the measured number.
By their numbers in this assay, from the lowest: compounds 4, 1, 2 and 3 (each within the scatter of the next).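

Swapping isopropyl for cyclopropyl on the amide-type nitrogen keeps the count of three carbons and adds a three-membered ring, and in this assay this gives a 1.5-fold lower number from compound 2 to compound 4 (0.16 log units; within the scatter). Within the data shown here, this is the first pair of compounds that differ only at this position, and it shows that this group can be closed into a ring without a step beyond the scatter. Nothing measured on these compounds accounts for the size of this step.

Among these compounds, only this one swap can be read at this position, so it remains open whether the same swap would give a similar step on another core, such as that of compound 1. From the compounds shown here alone, it is also open whether a longer chain such as n-butyl, or a larger ring such as cyclohexyl, on this nitrogen would move the number beyond the scatter.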